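Hydroxy addition on dimethoxybiphenyls in a breast cancer cell assay

The compounds below may be only part of what the source reports. "The series", "measured", "known", "first", "only" and "open" are said of these compounds alone.

Measured so far:
compound 1 `COc1ccc(-c2ccccc2)c(OC)c1` — > 100 ug/mL
compound 2 `COc1ccc(-c2cccc(O)c2)c(OC)c1` — 50.2 ug/mL
compound 3 `COc1ccc(-c2ccccc2)cc1OC` — 45 ug/mL

In a functional assay on MCF7 cells (Homo sapiens) for cytotoxicity, read by MTT assay, with a stated time of 3 days (a lower number here means a stronger inhibitor, a higher number a weaker inhibitor), compound 1 gives only a limit, > 100 ug/mL (the limit of > 100 ug/mL in this assay, at which 1 of the 3 values shown sits). Compound 2 carries a hydroxy in place of hydrogen on an aromatic carbon, and in this assay compound 2 gives 50.2 ug/mL. That change made an at least 1.9-fold lower number from compound 1 to compound 2 (0.29 log units; that floor lies within the scatter). Compound 3 has the same atoms as compound 1 joined differently; the difference between the two cores is not broken down here. In this assay compound 3 gives 45 ug/mL, within the scatter of compound 2. Compound 4 `COc1ccc(-c2ccc(O)cc2)cc1OC` carries the same kind of change (hydroxy in place of hydrogen on an aromatic carbon), though there the hydroxy sits para to a large group, whereas in compound 2 it sits meta to a large group. Compound 4 is expected to show a 1.8-fold lower number from compound 3 to compound 4 (0.26 log units; within the scatter), an expectation resting on an at least 1.9-fold lower number from compound 1 to compound 2 (0.29 log units; that floor lies within the scatter). The estimate for compound 4 is 25 ug/mL, from 10 ug/mL to 60 ug/mL.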

Compound 4, half-maximal inhibitory concentration: 34 ug/mL
Compound 4: middle estimate off by 1.4-fold (0.13 log units), on the low side; measured number inside the range.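

In this assay, hydroxy in place of hydrogen on an aromatic carbon, para to a large group, makes a 1.3-fold lower number from compound 3 to compound 4 (0.12 log units; within the scatter), so on this core the change cannot be told apart from the scatter of repeat measurements. Set beside the earlier case, the comparison stands as follows: the same change on two cores in this assay, an at least 1.9-fold lower number (0.29 log units; that floor lies within the scatter) from compound 1 to compound 2 and a 1.3-fold lower number (0.12 log units; within the scatter) from compound 3 to compound 4; the limit leaves it open whether they differ. Compound 1 gives only a limit, > 100 ug/mL, so the series neither shows that the change carries over from one core to the other with a similar size nor shows that it does not.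

The compounds shown leave open whether an amine or a carboxylic acid at the same place would move the number beyond the scatter. They also leave open how the two placements of the hydroxy compare on a single core.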